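Trimethoxyphenyl on a weakly growth-inhibiting methylpyridine compound

The compounds below may be only part of what the source reports. "The series", "measured", "known", "first", "only" and "open" are said of these compounds alone.

In a functional assay on HeLa cells (Homo sapiens) for inhibition, read by MTT assay, with a stated time of 48 h (on this read-out higher numbers stand for weaker inhibition of growth and lower numbers for stronger inhibition of growth), compound 1 `Cn1cc(C2CC(c3ccccc3)=NN2C(=O)c2cccnc2)c2ccccc21` gives > 10000 nM, which is a limit of the assay and not a number. Going by the values given here, compound 2 `Cc1ccc(C(=O)N2N=C(c3ccccc3)CC2c2cn(C)c3ccccc23)cn1` gives 2390 nM, the only actual number so far. Compound 3 `COc1cc(C2=NN(C(=O)c3ccc(C)nc3)C(c3cn(C)c4ccccc34)C2)cc(OC)c1OC` differs from it at one place, with 3,4,5-trimethoxyphenyl in place of phenyl on a carbon with a double bond to nitrogen. Among the compounds with values here, only one measured step exists, an at least 4.1-fold lower number from compound 1 to compound 2 (0.62 log units; beyond the scatter), made by methyl in place of hydrogen on an aromatic carbon. That step lies at another place, so it bears only indirectly, yet it suggests that one change can shift this series beyond the scatter. A shift towards stronger inhibition is therefore expected, though its direction is a judgement. The expected change is a 4.0-fold lower number from compound 2 to compound 3 (0.60 log units; beyond the scatter). For compound 3 the estimated value is 600 nM, within an expected range from 100 nM to 4000 nM.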

Compound 3, concentration for 50% growth inhibition: 210 nM
Estimate against measurement, compound 3: 2.9-fold (0.46 log units) above, and the stated range covers the measured number.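

In this assay, the carbon with a double bond to nitrogen of the five-membered ring proves to be a place where one change matters a great deal: 3,4,5-trimethoxyphenyl in place of phenyl gives an 11-fold lower number from compound 2 to compound 3 (1.06 log units; beyond the scatter). The aromatic ring at this place can therefore carry added methoxy groups, and inhibition of growth becomes stronger rather than being lost. Unlike the earlier step, which starts from compound 1, whose value is a limit of the assay and not a number, this step joins two measured numbers, so its full size can be read: the limit of > 10000 nM in this assay, at which 1 of the 3 values shown sits.

The compounds shown cannot tell whether a single methoxy group, or an amine or a carboxylic acid on the phenyl, would have a similar effect. As far as these compounds go, it also remains open whether 3,4,5-trimethoxyphenyl would give a similar step on the core of compound 1.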